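A few compounds are considered here, and "the series" means these few. Any claim that something is new, unique, unknown or untested is made for them only; others in the source may bear on it.

Measured so far in a functional assay on MCF7 cells (Homo sapiens) for antiproliferative activity, read by MTT assay, with a stated time of 72 h; on this read-out higher numbers stand for weaker inhibition and lower numbers for stronger inhibition:
- compound 1 (`CCN(CC)CCNc1ncnc2ccc(-c3ccc(OC)nc3)cc12`): 8740 nM
- compound 2 (`COc1ccc(-c2ccc3ncnc(NCCN4CCCCC4)c3c2)cn1`): 2420 nM
- compound 3 (`CCN(CC)CCNc1ncnc2ccc(-c3cnc(OC)c([N+](=O)[O-])c3)cc12`): 16300 nM

Compound 2 has the lowest of the three numbers, and both gaps to it lie beyond the scatter. Compound 4 (`COc1ncc(-c2ccc3ncnc(NCCN4CCCCC4)c3c2)cc1C#N`) differs from compound 2 by cyano in place of hydrogen on an aromatic carbon (cyano in place of hydrogen on an aromatic carbon, ortho to a methoxy group). The closest measured change, nitro in place of hydrogen on an aromatic carbon, gives a 1.9-fold higher number from compound 1 to compound 3 (0.27 log units; within the scatter) (within the scatter). The step of a 3.6-fold lower number from compound 1 to compound 2 (0.56 log units; beyond the scatter) lies in the side chain, which is unchanged here, so it adds nothing to the size expected. In this assay the expected step, which stays within the scatter, is a 1.5-fold higher number from compound 2 to compound 4 (0.17 log units; within the scatter) (an estimate). The estimate for compound 4 is 3600 nM (expected range 1500 nM to 9000 nM).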

Compound 4, half-maximal inhibitory concentration: 2740 nM
Compound 4: the middle estimate sits 1.3-fold (0.12 log units) above what was measured, and the stated range covers the measured number.
By their numbers in this assay, from the lowest: compounds 2 and 4 (each within the scatter of the next); then compounds 1 and 3 (each within the scatter of the next).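

In this assay cyano in place of hydrogen on an aromatic carbon, ortho to a methoxy group, gives a 1.1-fold higher number from compound 2 to compound 4 (0.05 log units; within the scatter) and so leaves compound 2 and compound 4 indistinguishable on this read-out. The earlier reading at this position came from nitro with the diethylamino side chain, whereas this one comes from cyano with the piperidin-1-yl side chain. Nothing available explains this result. From the compounds shown here alone, whether an amine or a carboxylic acid at this position would also stay within the scatter of compound 2 remains open.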